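The compounds below may be only part of what the source reports. "The series", "measured", "known", "first", "only" and "open" are said of these compounds alone.

Three related compounds have been tested in a functional assay on CCRF-CEM cells (Homo sapiens) for cytotoxicity, in the absence of a further agent; a lower number here means a stronger inhibitor, a higher number a weaker inhibitor. Compound 1 `Nc1nc(N)c(CCCNc2cc(F)ccc2[N+](=O)[O-])c(O)n1` gives no number there, only a limit, > 100000 nM. Compound 2 `CC(C)(C)OC(=O)CCC(Nc1ccc(CN(CCCc2c(N)nc(N)nc2O)c2cc(F)c([N+](=O)[O-])cc2[N+](=O)[O-])cc1)C(=O)OC(C)(C)C` gives 2600 nM. Compound 3 `CC(C)(C)OC(=O)CCC(Nc1ccc(CN(CCCc2c(N)nc(N)nc2O)c2cc(F)cc(F)c2[N+](=O)[O-])cc1)C(=O)OC(C)(C)C` gives 17000 nM, the higher of the two actual numbers, and the gap between compound 2 and compound 3 lies beyond the scatter of repeated measurements.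

The next compound stays close to compound 3. Compound 4 `CC(C)(C)OC(=O)CCC(Nc1ccc(CN(CCCc2c(N)nc(N)nc2O)c2cc(F)ccc2[N+](=O)[O-])cc1)C(=O)OC(C)(C)C` carries hydrogen in place of fluoro on an aromatic carbon, ortho to a nitro group, so that 3,5-difluoro-2-nitrophenyl becomes 5-fluoro-2-nitrophenyl: hydrogen in place of fluoro on an aromatic carbon.

For the measured compounds named here, no measured pair in this small set isolates a single change, so the size of this step in this assay cannot be read directly from the data. Going by the values given here, the only guide is the spread between two compounds that differ on the same aromatic ring, compound 2 at 2600 nM and compound 3 at 17000 nM. With so little to go on, no shift beyond the scatter is expected, and the range is kept wide. The expected step is a 1.3-fold lower number from compound 3 to compound 4 (0.12 log units; within the scatter). For compound 4 the estimated value is 13000 nM, with an expected range from 3500 nM to 45000 nM.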

Compound 4, half-maximal inhibitory concentration: 3400 nM
For compound 4 the middle estimate is 3.8-fold (0.58 log units) above the measured one; the measured number lies below the stated range.
By their numbers in this assay, from the lowest: compounds 2 and 4 (each within the scatter of the next); then compound 3. At a limit, above all of these: compound 1.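

In this assay, for the compounds shown here, a 5.0-fold lower number from compound 3 to compound 4 (0.70 log units; beyond the scatter) gives the first reading of a change in one place. It shows that hydrogen in place of fluoro on this aromatic carbon, ortho to a nitro group, moves the number beyond the scatter, with the fluoro compound giving the higher number. A second change on the same ring, in which a nitro group gives way to hydrogen, gives a 1.3-fold higher number from compound 2 to compound 4 (0.12 log units; within the scatter), so not every single change on this ring moves the number beyond the scatter. Nothing measured here bears on why the fluoro step has this size.

From the compounds shown here alone, whether this carbon responds only to fluoro or also to other groups stays open, since a chloro, methyl, methoxy or amine there would show whether the higher number is particular to fluoro. Going by these compounds, it is also open whether the same step holds when the two tert-butyl esters are replaced by free carboxylic acids.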